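Swapping 4-Methoxyphenyl for 2-Phenylethenyl on a Shared Core

This account rests on a few compounds, and the source may have more. Where it says the series, first, only, none or still open, it means among the compounds named here.

Compound 2 `COc1ccc(-c2cc(C(C)=O)c3[nH]c(-c4ccc(F)cc4)cc3c2)cc1` has been tested in a functional assay on HeLa cells (Homo sapiens) for cytotoxicity, read by MTT assay, with a stated time of 2 days, tested at 10 uM (on this read-out lower numbers stand for a stronger effect and higher numbers for a weaker effect at the one concentration tested), where it gives 46.5%. Among the two numbers known so far it stands lowest, and its nearest neighbour is compound 1 `CC(=O)c1cc(-c2ccc(F)cc2)cc2cc(-c3ccc(F)cc3)[nH]c12`, which in this assay gives 47.4%. The step of a number 0.9 percentage points lower from compound 1 to compound 2 (within the scatter) lies within the scatter, so these two compounds cannot be told apart on this read-out. Compound 3 `CC(=O)c1cc(/C=C/c2ccccc2)cc2cc(-c3ccc(F)cc3)[nH]c12` has not yet been measured. It differs from compound 2 in one place: 2-phenylethenyl in place of 4-methoxyphenyl on an aromatic carbon. Among the compounds with values here, the only step measured so far, a number 0.9 percentage points lower from compound 1 to compound 2 (within the scatter), exchanged a single small group within the 4-methoxyphenyl unit and changed nothing beyond the scatter; it offers no direct guide for replacing that whole unit with 2-phenylethenyl. Lacking a closer precedent, the expected step is a number 0.5 percentage points lower from compound 2 to compound 3 (within the scatter), meaning none beyond the scatter. Compound 3 is therefore estimated at 46%, within a range from 28% to 64%.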

Compound 3, a percentage reported as activity, at one concentration (the size of the read-out at that concentration, not a potency): 51.9%
For compound 3 the middle estimate is 5.9 percentage points below the measured one; measured number inside the range.
By their numbers in this assay, from the lowest: compounds 2, 1 and 3 (each within the scatter of the next).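

Replacing 4-methoxyphenyl with 2-phenylethenyl gives a number 5.4 percentage points higher from compound 2 to compound 3 (within the scatter) in this assay, and replacing 4-fluorophenyl with 2-phenylethenyl gives a number 4.5 percentage points higher from compound 1 to compound 3 (within the scatter). Unlike the earlier step, which altered only a small group on the aromatic ring, these steps exchange the whole unit at this position, bringing in a double bond outside aromatic rings, yet no difference beyond the scatter appears. No evidence on the cause of these results is available here.

Going by these compounds, whether an amine or a carboxylic acid at this position, or a longer chain in place of 2-phenylethenyl, would move the number beyond the scatter remains open. So does the effect of changing the acetyl group, which all three compounds share.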